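The source may hold more compounds than are shown below. What is called first, only, known or untested is meant among the compounds shown, and "the series" means these compounds.

Compound 1 `CCOC(=O)C1=C(CC)NC(=O)NC1c1ccco1` gives 3%.
Compound 2 `CC1=C(C(=O)OC(C)C)C(c2ccco2)NC(=O)N1C` gives 18%.
Compound 3 `CCOC(=O)C1=C(C)NC(=S)NC1c1ccoc1` gives 15%.

All three were tested in an assay on HeLa cells for displacement of a labelled ligand from adenosine receptor A3 (Homo sapiens), with a stated time of 180 min, tested at 10 uM; a higher number here means more inhibition at the concentration tested (going by the name of the read-out), a lower number less inhibition. Compound 3 holds the second highest of the three numbers. Its nearest neighbour is compound 2, whose number lies higher by a gap within the usual scatter, so the two cannot be told apart on these data. The furthest is compound 1, whose number lies well below, a gap beyond the scatter.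

Compound 4 `CC1=C(C(=O)OC(C)C)C(c2ccoc2)NC(=S)N1` has not yet been measured in this assay . It differs from compound 3 in one place only: methyl in place of hydrogen on a saturated chain carbon bound to an oxygen next to a carbonyl group and a saturated chain carbon. Read one bond further out, the change is ethoxycarbonyl to isopropoxycarbonyl.

Going by the values given here, no pair of measured compounds differs in just this one place, so the data hold no direct step of this kind. Compound 2 carries the isopropoxycarbonyl group and compound 3 the ethoxycarbonyl group, but they differ elsewhere too, and their values sit within the scatter of each other. The step from compound 3 to compound 4 is therefore expected to be small, and is estimated at a number 2 percentage points higher from compound 3 to compound 4 (within the scatter), with no clear direction. Compound 4 is expected to give about 17%, in a range from 5% to 30%.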

Compound 4, a percentage reported as inhibition, at one concentration (the size of the read-out at that concentration, not a potency): 23%
For compound 4 the middle estimate is 6 percentage points below the measured one; measured number inside the range.
By their numbers in this assay, from the lowest: compound 1; then compounds 3, 2 and 4 (each within the scatter of the next).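

Going by these compounds alone, compound 3 and compound 4 form the first measured pair that differs in one place only, so the change from ethoxycarbonyl to isopropoxycarbonyl can now be read on its own rather than through compounds that also differ elsewhere. In this assay, adding this methyl on the saturated chain carbon bound to an oxygen gives a number 8 percentage points higher from compound 3 to compound 4 (within the scatter), so on this single pair, ethyl and isopropyl at this position cannot be told apart. No independent measurement is available to explain this result.

This is one step on one core, read at a single concentration, so it gives no potency and leaves open whether the same change would give a similar result on the core of compound 1 or compound 2. It also leaves open what a clearly different group at this position would do, such as a longer chain like butyl, a cyclopentyl ring, or a carboxylic acid in place of the whole ethoxycarbonyl group.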